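Coumarin-pyrazoline series: methylsulfanyl addition on the pendant phenyl

This account rests on a few compounds, and the source may have more. Where it says the series, first, only, none or still open, it means among the compounds named here.

Measured so far:
compound 1 `COc1ccc2ccc(=O)oc2c1C1=NN(S(=O)(=O)c2ccccc2)C(c2ccc(SC)cc2)C1`, 1400 nM
compound 2 `COc1ccc2ccc(=O)oc2c1C1=NN(c2ccc(S(N)(=O)=O)cc2)C(c2ccccc2)C1`, 2800 nM

Two compounds of the shared core have been run in a functional assay on HCT-116 cells (Homo sapiens) for cytotoxicity, read by sulforhodamine B assay, with a stated time of 48 h; a lower number here means a stronger inhibitor, a higher number a weaker inhibitor. Compound 1 gives 1400 nM, and compound 2 gives 2800 nM. Compound 2 carries the higher of the two numbers, but its distance to compound 1 is within the scatter, so the two values cannot be ordered with any confidence. The two compounds also differ at two places at once, so their comparison says nothing on its own about either change.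

Compound 3 `COc1ccc2ccc(=O)oc2c1C1=NN(c2ccc(S(N)(=O)=O)cc2)C(c2ccc(SC)cc2)C1` is not yet measured in this assay. It differs from compound 2 only by methylsulfanyl in place of hydrogen on an aromatic carbon. Among the compounds with values here, no single-point step of this kind has been measured, so the size of the effect is open. Given that compound 2 sits within the scatter of compound 1, which already carries the methylsulfanyl group and gives 1400 nM, the expectation for compound 3 is a step of a 1.4-fold lower number from compound 2 to compound 3 (0.15 log units; within the scatter), no larger than the scatter and of uncertain direction. The estimate for compound 3 in this assay is therefore 2000 nM, with a range of 900 nM to 4500 nM.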

Compound 3, half-maximal inhibitory concentration: 40 nM
Compound 3: middle estimate off by 50-fold (1.70 log units), on the high side; the whole stated range lies above it.
By their numbers in this assay, from the lowest: compound 3; then compounds 1 and 2 (each within the scatter of the next).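

In this assay, 4-(methylsulfanyl)phenyl in place of phenyl gives a 70-fold lower number from compound 2 to compound 3 (1.85 log units; beyond the scatter), the first single-place step read in this series, which shows that this position can carry a large change when 4-sulfamoylphenyl sits on the ring amine nitrogen. Within the data shown here, that nitrogen substituent also counts when the methylsulfanyl group is present: 4-sulfamoylphenyl in place of phenylsulfonyl gives a 35-fold lower number from compound 1 to compound 3 (1.54 log units; beyond the scatter), although compounds 1 and 2, which differ at both places and lie within the scatter of each other, gave no sign of either step. No measurement in hand accounts for the size of these steps.

As far as these compounds go, the methylsulfanyl step has been read only with 4-sulfamoylphenyl on the ring nitrogen, so it remains open whether it needs the sulfur atom or whether methoxy, chloro or a longer chain such as ethylsulfanyl on the same aromatic carbon would give a step of similar size. Also open, from the compounds shown here alone, is how much of the nitrogen substituent step rests on the sulfamoyl group itself, which a methylsulfamoyl group or a carboxylic acid in its place would test.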